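Replacing a dibromophenyl with a hydroxypyridinyl on a shared core

This account rests on a few compounds, and the source may have more. Where it says the series, first, only, none or still open, it means among the compounds named here.

Three compounds share one core and differ only in the aromatic ring attached to a double-bonded chain carbon bound to a double-bonded ring carbon. Compound 1 `O=C1Nc2ccc(C(=O)c3ccco3)cc2/C1=C/c1cc(Br)c(O)c(Br)c1` carries a 3,5-dibromo-4-hydroxyphenyl there, and in an assay on HeLa cells for inhibition of Kinesin-like protein KIF15 (Homo sapiens), read by microscopy, with stated times of 2 s and 20 s, tested at 750 nM (a higher number here means more inhibition at the concentration tested (going by the name of the read-out), a lower number less inhibition), compound 1 gives 65%. Compound 2 `O=C1Nc2ccc(C(=O)c3ccco3)cc2/C1=C/c1cc(I)c(O)c(I)c1` carries a 4-hydroxy-3,5-diiodophenyl, and in this assay compound 2 gives 26%. Compound 3 `O=C1Nc2ccc(C(=O)c3ccco3)cc2/C1=C/c1cc(Br)cc(Br)c1` carries a 3,5-dibromophenyl, and in this assay compound 3 gives 16%, the lowest of the three numbers; it sits a number 10 percentage points lower from compound 2 to compound 3 (within the scatter) and a number 49 percentage points lower from compound 1 to compound 3 (beyond the scatter).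

The step from compound 3 to compound 4 `O=C1Nc2ccc(C(=O)c3ccco3)cc2/C1=C/c1ccc(O)nc1` is 6-hydroxypyridin-3-yl in place of 3,5-dibromophenyl on a double-bonded chain carbon bound to a double-bonded ring carbon. For the measured compounds named here, the one measured step that bears on it is the loss of the hydroxy, a number 49 percentage points lower from compound 1 to compound 3 (beyond the scatter), a large drop. Going by the values given here, compound 4 brings a hydroxy back, though on a different ring and without the two bromines, for which no measured step exists. A moderate rise in this assay is therefore expected, well short of compound 1, with wide uncertainty.

Compound 4 is estimated to give 30% in this assay, between 5% and 60%, which means an expected step of a number 14 percentage points higher from compound 3 to compound 4 (beyond the scatter).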

Compound 4, a percentage reported as inhibition, at one concentration (the size of the read-out at that concentration, not a potency): 26.5%
The estimate for compound 4 lay 3.5 percentage points above the measured number; the range from low to high includes it.
By their numbers in this assay, from the lowest: compounds 3, 2 and 4 (each within the scatter of the next, the first and the last beyond it); then compound 1.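

In this assay, a ring with a hydroxy and no halogen at all reads a number 10.5 percentage points higher from compound 3 to compound 4 (beyond the scatter), so at this position the two bromines are not required to rise beyond the scatter from the number of the dibromophenyl compound, and the hydroxy-bearing pyridine ring also reads a number 0.5 percentage points higher from compound 2 to compound 4 (within the scatter), which leaves it indistinguishable from the diiodinated phenol. Yet a hydroxy on this smaller ring falls well short of the best compound, at a number 38.5 percentage points lower from compound 1 to compound 4 (beyond the scatter), so a hydroxy alone does not recover the number given by the 3,5-dibromo-4-hydroxyphenyl group. Nothing in the available data explains these differences.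

This one swap changes the ring atoms, the hydroxy and the halogens together, so the compounds shown cannot separate the share of the ring nitrogen from that of the hydroxy. A phenyl ring carrying only a hydroxy, an amine in the place of that hydroxy, or a hydroxypyridinyl ring that also carries bromine would each pull those contributions apart.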